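Swapping Chloro for Bromo on the Shared Core

The source may report more compounds than this note shows. Statements on the series, on what has been measured and on what is new or still open speak of the compounds shown alone.

Compound 1 `Cc1ccc(C(=O)N/N=C/c2ccccc2O)c(O)c1` and compound 2 `Cc1ccc(C(=O)N/N=C/c2cc(Cl)ccc2O)c(O)c1` share one core and differ at a single aromatic carbon. In an ADME assay on cells (Mus musculus, strain BALB/C) for cytotoxicity, read by MTT assay, with a stated time of 24 h (on this read-out lower numbers stand for higher toxicity in this test and higher numbers for lower toxicity in this test), compound 1 gives 761000 nM. In this assay compound 2 gives 560000 nM, which lies within the usual scatter of the value for compound 1, so the two cannot be ranked.

The next compound is compound 3 `Cc1ccc(C(=O)N/N=C/c2cc(Br)ccc2O)c(O)c1`, and the change is bromo in place of chloro on an aromatic carbon. In words, bromo takes the place of chloro on an aromatic carbon, para to a hydroxy group.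

Among the compounds with values here, only one measured step bears on this swap: putting chloro in place of hydrogen, a 1.4-fold lower number from compound 1 to compound 2 (0.13 log units; within the scatter). That step stayed inside the scatter, so there is no ground for expecting a real move in this assay in either direction, although a single step is thin evidence. The expected change is a 1.1-fold lower number from compound 2 to compound 3 (0.02 log units; within the scatter), which is no more than the scatter. Compound 3 is expected to read about 530000 nM, with an estimated range of 300000 nM to 900000 nM.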

Compound 3, half-maximal cytotoxic concentration: 1500000 nM
For compound 3 the middle estimate is 2.8-fold (0.45 log units) below the measured one, outside the stated range (above it).
By their numbers in this assay, from the lowest: compounds 2, 1 and 3 (each within the scatter of the next, the first and the last beyond it).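

In this assay, the aromatic carbon para to a hydroxy group now shows its first step beyond the scatter, a 2.7-fold higher number from compound 2 to compound 3 (0.43 log units; beyond the scatter), so the choice between chloro and bromo can register at this position, though the step is modest. Neither group clearly separates from hydrogen, however: bromo gives a 2.0-fold higher number from compound 1 to compound 3 (0.29 log units; within the scatter), and chloro gives a 1.4-fold lower number from compound 1 to compound 2 (0.13 log units; within the scatter), both of which lie within the scatter, so only the two halogen compounds can be told apart, and a higher number here stands for lower toxicity in this test. No measurement is available to explain why this swap has the effect it does.

The compounds shown cover only hydrogen, chloro and bromo at this one carbon, so how an amine, a carboxylic acid or a longer chain would read there remains open. Also open, on these data alone, is whether the same swap from chloro to bromo would give a similar step on another carbon of the shared core.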